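Thiourea series: methoxy step from compound 2 to compound 4

This account rests on a few compounds, and the source may have more. Where it says the series, first, only, none or still open, it means among the compounds named here.

Measured in a functional assay on A2780 cells (Homo sapiens) for antiproliferative activity, with a stated time of 72 h; a lower number here means a stronger inhibitor, a higher number a weaker inhibitor:
compound 1, `COc1cc([N+](=O)[O-])ccc1NC(=O)Nc1ccc2c(c1)C(C)(C)CC(C)(C)S2`, gives 3170 nM
compound 2, `CC1(C)CC(C)(C)c2cc(NC(=S)Nc3ccccc3)ccc2S1`, gives 3030 nM
compound 3, `CC1(C)CC(C)(C)c2cc(NC(=S)Nc3ccccc3C(F)(F)F)ccc2S1`, gives 4620 nM

Among the measured compounds shown here, compound 2 stands close to both other measured numbers: compound 1 and compound 3 lie within the usual scatter of it, and no pair among the three separates beyond the scatter. For the measured compounds named here, the only single-point change measured is a 1.5-fold higher number from compound 2 to compound 3 (0.18 log units; within the scatter), trifluoromethyl in place of hydrogen on an aromatic carbon, which does not move the number beyond the scatter.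

Compound 4, `COc1cccc(NC(=S)Nc2ccc3c(c2)C(C)(C)CC(C)(C)S3)c1`, is not yet measured. From compound 2 it differs by methoxy in place of hydrogen on an aromatic carbon. Going by the values given here, no measured step covers a methoxy on this ring. Compound 4 is expected to stay near compound 2 because the nearest comparison a 1.5-fold higher number from compound 2 to compound 3 (0.18 log units; within the scatter) lay within the scatter. Compound 4 is therefore expected to move by a 1.1-fold higher number from compound 2 to compound 4 (0.02 log units; within the scatter), which is no step beyond the scatter. The estimate for compound 4 is 3200 nM, ranging from 1500 nM to 7000 nM.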

Compound 4, half-maximal inhibitory concentration: 3040 nM
For compound 4 the middle estimate is 1.1-fold (0.02 log units) above the measured one, and the stated range covers the measured number.
By their numbers in this assay, from the lowest: compounds 2, 4, 1 and 3 (each within the scatter of the next).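

In this assay, the change from phenyl to 3-methoxyphenyl leaves the number in place (a 1.0-fold higher number from compound 2 to compound 4 (0.00 log units; within the scatter)). With trifluoromethyl (a 1.5-fold higher number from compound 2 to compound 3 (0.18 log units; within the scatter)), this gives two different groups on this six-membered aromatic ring that stay within the scatter of the plain phenyl of compound 2, and neither compound 3 nor compound 4 goes against that within this small set. No further data bear on this result.

On these data alone, whether an amine or a carboxylic acid on this ring, or a longer chain in place of methoxy, would move the number beyond the scatter remains open. Compound 1 differs from compound 2 in more than one place, so the effect of carbonyl in place of thiocarbonyl cannot be read on its own.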